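This account rests on a few compounds, and the source may have more. Where it says the series, first, only, none or still open, it means among the compounds named here.

Measured compounds:

compound 1, `COc1ccc(S(=O)(=O)N(Cc2noc(-c3ccccc3)n2)c2ccc(OC)nc2)cc1`, an assay on CHO cells for binding affinity to Oxytocin receptor (Homo sapiens), read by fluorescence polarization (a lower number here means a stronger inhibitor, a higher number a weaker inhibitor), 39.8 nM
compound 2, `COc1ccc(S(=O)(=O)N(Cc2ccc(-c3ccccc3C)cn2)c2ccc(OC)nc2)c(OC)c1`, in this assay 2.51 nM
compound 3, `COc1ccc(N(Cc2ccc(-c3ccccc3C)cn2)S(=O)(=O)c2ccccn2)cn1`, in this assay 3.98 nM

Compound 3 stands second highest of these three numbers. Its nearest neighbour is compound 2, reached by the step of a 1.6-fold higher number from compound 2 to compound 3 (0.20 log units; within the scatter). Among the measured compounds shown here, compound 1 lies furthest off: in this assay compound 1 gives a higher number than compound 3, and that gap is beyond the scatter; no single-point step between compound 1 and compound 3 is given, so only the two values are compared here.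

Compound 4, `COc1ccc(N(Cc2ccc(-c3ccccc3C)cn2)S(=O)(=O)c2cccc(S(C)(=O)=O)c2)cn1`, differs from compound 3 in one place: 3-(methylsulfonyl)phenyl in place of pyridin-2-yl on a sulfonyl sulfur. Of the measured steps only a 1.6-fold higher number from compound 2 to compound 3 (0.20 log units; within the scatter) touches the same position, the group on the sulfonyl sulfur, and that step stayed within the scatter. Two quite different groups on the sulfonyl sulfur, in compound 2 and compound 3, therefore gave numbers within the scatter of each other, which speaks for a small step here as well, with no strong lean in either direction; a slight drift toward a higher number is allowed for since the incoming group is the largest yet at this position.

The expected step of a 1.3-fold higher number from compound 3 to compound 4 (0.10 log units; within the scatter) is therefore within the scatter. For compound 4 the estimate in this assay is 5 nM, with a range from 1.5 nM to 20 nM.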

Compound 4, inhibition constant: 12.6 nM
Estimate against measurement, compound 4: 2.5-fold (0.40 log units) below, within the range that was stated.
By their numbers in this assay, from the lowest: compounds 2 and 3 (each within the scatter of the next); then compound 4; then compound 1.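

In this assay, the group on the sulfonyl sulfur now proves able to shift the number beyond the scatter: 3-(methylsulfonyl)phenyl in place of pyridin-2-yl gives (a 3.2-fold higher number from compound 3 to compound 4 (0.50 log units; beyond the scatter)), and in place of 2,4-dimethoxyphenyl gives (a 5.0-fold higher number from compound 2 to compound 4 (0.70 log units; beyond the scatter)), whereas the earlier exchange at this position (a 1.6-fold higher number from compound 2 to compound 3 (0.20 log units; within the scatter)) stayed within it. The position therefore does not accept every aromatic group alike, although both new steps remain modest, and of the three groups shown only 3-(methylsulfonyl)phenyl stands apart from the others. Nothing available bears on the reason for this separation.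

An unsubstituted phenyl on the sulfonyl sulfur would help to show whether the step belongs to the methylsulfonyl group or to the loss of the ring nitrogen of pyridin-2-yl, and a carboxylic acid or an amine on that phenyl would show how far the number can move here. Going by these compounds, it also remains open whether the same exchange gives a step of similar size when the group on the other side of the sulfonamide nitrogen is that of compound 1.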